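Phenyl to tert-butoxy on the side chain: clearance notes

A few compounds are considered here, and "the series" means these few. Any claim that something is new, unique, unknown or untested is made for them only; others in the source may bear on it.

Measured compounds:
compound 1 `O=C(NCc1cc(Cl)ccc1-n1cnnn1)[C@@H]1[C@H]2C[C@H]2CN1C(=O)[C@H](O)CC1CC1` — < 14 mL.min-1.g-1 (a limit of the assay)
compound 2 `O=C(NCc1cc(Cl)ccc1-n1cnnn1)[C@@H]1[C@H]2C[C@H]2CN1C(=O)[C@H](O)Cc1ccccc1` — 96 mL.min-1.g-1
compound 3 `O=C(NCc1cc(Cl)ccc1-n1cnnn1)[C@@H]1C[C@@H]2C[C@@H]2N1C(=O)[C@H](O)c1ccccc1F` — < 12 mL.min-1.g-1 (a limit of the assay)

Within the data shown here, in an ADME assay on liver for metabolic stability, with Liver microsome (Homo sapiens) as the target, read by LC-MS, using microsomes (a lower number here means slower removal, a higher number faster removal of the compound), compound 2 gives 96 mL.min-1.g-1, the only plain number among the three values shown. Compound 1 sits at the limit of < 14 mL.min-1.g-1 in this assay, at which 1 of the 3 values shown sits. Compound 3 sits at the limit of < 12 mL.min-1.g-1 in this assay, at which 1 of the 3 values shown sits. Among the measured compounds shown here, the single measured step with a bearing on the question is an at least 6.8-fold higher number from compound 1 to compound 2 (0.83 log units; beyond the scatter), which brought the phenyl in and moved the number off the limit.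

Compound 4 `CC(C)(C)OC[C@@H](O)C(=O)N1C[C@@H]2C[C@@H]2[C@H]1C(=O)NCc1cc(Cl)ccc1-n1cnnn1` is the untested member. Its change from compound 2 reads: tert-butoxy in place of phenyl on a saturated chain carbon, two bonds along the chain from a carbonyl carbon and an oxygen on a saturated carbon. For the measured compounds named here, this removes the very phenyl whose arrival marked the one measured step, so a lower number is expected for compound 4 because an at least 6.8-fold higher number from compound 1 to compound 2 (0.83 log units; beyond the scatter) went the other way when that phenyl entered. Nothing measured speaks to tert-butoxy itself at this position, so the size remains uncertain. For compound 4 in this assay the expected value is 22 mL.min-1.g-1, with a range from 8 mL.min-1.g-1 to 55 mL.min-1.g-1. The estimated step is therefore a 4.4-fold lower number from compound 2 to compound 4 (0.64 log units; beyond the scatter).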

Compound 4, intrinsic clearance in microsomes: 37 mL.min-1.g-1
For compound 4 the middle estimate is 1.7-fold (0.23 log units) below the measured one; measured number inside the range.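

Replacing the phenyl with tert-butoxy in this assay gives a 2.6-fold lower number from compound 2 to compound 4 (0.41 log units; beyond the scatter), so an aromatic ring is not required for a plain number at this position. Set against cyclopropyl, the same position gives an at least 2.6-fold higher number from compound 1 to compound 4 (0.42 log units; beyond the scatter), so phenyl is not the only group here that lifts the number off the limit. That second step starts from a limit of the assay, not a number: the limit of < 14 mL.min-1.g-1 in this assay, at which 1 of the 4 values shown sits.

The compounds shown leave open how the step divides between the ether oxygen and the tert-butyl carbons, and how an amine, a carboxylic acid or a longer chain would read at this position. Compound 3 differs from the others in more than one place, so the steps involving it cannot be read.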